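Aryl urea series: trifluoromethyl to chloro swap

The source may hold more compounds than are shown below. What is called first, only, known or untested is meant among the compounds shown, and "the series" means these compounds.

Measured so far:
compound 1 `COc1cc2cc(Oc3ccc(NC(=O)Nc4cccc(C(F)(F)F)c4)cc3)c(C)nc2cc1OC`: 1320 nM
compound 2 `COc1cc2cc(Oc3ccc(NC(=O)Nc4ccc(Cl)c(C(F)(F)F)c4)cc3)c(C)nc2cc1OC`: 782 nM

In a functional assay on CAKI-1 cells (Homo sapiens) for inhibition, read by sulforhodamine B assay, with a stated time of 48 h (a higher number here means a weaker inhibitor of growth, a lower number a stronger inhibitor of growth), compound 2 holds the lowest of the two numbers; the nearest is compound 1, separated by a 1.7-fold lower number from compound 1 to compound 2 (0.23 log units; within the scatter). Compound 3 `COc1cc2cc(Oc3ccc(NC(=O)Nc4ccc(Cl)c(Cl)c4)cc3)c(C)nc2cc1OC` differs from compound 2 by chloro in place of trifluoromethyl on an aromatic carbon. Within the data shown here, no measured step covers this exchange; the single known step, a 1.7-fold lower number from compound 1 to compound 2 (0.23 log units; within the scatter), concerns a different change and lies within the scatter, so it offers no direction. For compound 3 the expected step is a 1.2-fold higher number from compound 2 to compound 3 (0.06 log units; within the scatter), none beyond the scatter. The estimate for compound 3 is 900 nM, with a range from 400 nM to 2000 nM.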

Compound 3, concentration for 50% growth inhibition: 2120 nM
The estimate for compound 3 lay 2.4-fold (0.37 log units) below the measured number, and the stated range ends below it.
By their numbers in this assay, from the lowest: compounds 2, 1 and 3 (each within the scatter of the next, the first and the last beyond it).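

In this assay, among these compounds, chloro in place of trifluoromethyl at this position, ortho to a chloro group, gives a 2.7-fold higher number from compound 2 to compound 3 (0.43 log units; beyond the scatter), the first step beyond the scatter. The 3,4-dichlorophenyl group in place of 3-(trifluoromethyl)phenyl gives a 1.6-fold higher number from compound 1 to compound 3 (0.21 log units; within the scatter), so that pair stays unseparated. No measurement at hand bears on what lies behind these steps.

Open, from the compounds shown here alone, is how a nitrile, a methoxy group or an amine would read at this position. Also open, going by these compounds, is whether the same exchange gives a step of this size without the neighbouring chloro group.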